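Carboxylic acid series: trifluoromethyl step from compound 2

The source may hold more compounds than are shown below. What is called first, only, known or untested is meant among the compounds shown, and "the series" means these compounds.

Measured so far in an assay on cells for inhibition of Palmitoleoyl-protein carboxylesterase NOTUM variant C330S (Homo sapiens), read by fluorescence, with a stated time of 40 min; a higher number here means a weaker inhibitor, a lower number a stronger inhibitor:
Compound 1 `CCOc1cccc(-n2c(C)cc(C(=O)O)c2C)c1` gives 640 nM.
Compound 2 `Cc1c(C(=O)O)ccn1Cc1ccccc1` gives 3100 nM.

Compound 2 carries the higher of the two numbers in this assay; compound 1 sits lower by a gap beyond the usual scatter. Compound 3 `Cc1c(C(=O)O)cc(C(F)(F)F)n1Cc1ccccc1` differs from compound 2 by trifluoromethyl in place of hydrogen on an aromatic carbon. Among the measured compounds shown here, no measured pair shows this change, so the expected step rests only on the structural change itself; a moderate move toward a lower number is expected, as a 2.8-fold lower number from compound 2 to compound 3 (0.45 log units; beyond the scatter). Compound 3 is estimated at 1100 nM, within a range from 350 nM to 3500 nM.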

Compound 3, half-maximal inhibitory concentration: > 100000 nM
Compound 3: only a limit was reported; the forecaster's own chance of this, stated with the estimate: 5%; middle value at least 90-fold (1.95 log units) from the limit.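

On the aromatic carbon next to the ring nitrogen, trifluoromethyl in place of hydrogen gives an at least 32-fold higher number from compound 2 to compound 3 (1.50 log units; beyond the scatter) in this assay. This position is therefore not indifferent to substitution: a single change here moves compound 2 strongly toward weaker inhibition. Compound 3 stands only as a limit of the assay, not as a number: the limit of > 100000 nM in this assay, at which 1 of the 3 values shown sits.

On these data alone, whether a chlorine, a nitrile or an amine on this carbon would keep the inhibition of compound 2 stays open. As far as these compounds go, the true size of the step also stays open.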